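Aryl-Triazole Replacement and Expected Cytotoxicity for Compound 4

The source may report more compounds than this note shows. Statements on the series, on what has been measured and on what is new or still open speak of the compounds shown alone.

Measured compounds in an ADME assay on MT4 cells (Homo sapiens) for cytotoxicity, read by MTT assay, with a stated time of 5 days; on this read-out higher numbers stand for lower toxicity in this test and lower numbers for higher toxicity in this test:
compound 1 `Cc1cc(C)c(Oc2cc(Nc3ccc(C#N)cc3)ncc2C(=O)NCc2cn(Cc3cccc(Cl)c3)nn2)c(C)c1`: 187000 nM
compound 2 `COC(=O)Cn1cc(CNC(=O)c2cnc(Nc3ccc(C#N)cc3)cc2Oc2c(C)cc(C)cc2C)nn1`: 13800 nM
compound 3 `CCOC(=O)CCn1cc(CNC(=O)c2cnc(Nc3ccc(C#N)cc3)cc2Oc2c(C)cc(C)cc2C)nn1`: 21500 nM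

Compound 3 stands second highest of the three numbers in this assay; its nearest neighbour, compound 2, lies within the scatter of it, while compound 1 gives a far higher number. Compound 4 `Cc1cc(C)c(Oc2cc(Nc3ccc(C#N)cc3)ncc2C(=O)NCc2cn(Cc3cccc([N+](=O)[O-])c3)nn2)c(C)c1` differs from compound 3 by 3-nitrophenyl in place of (ethoxycarbonyl)methyl on a saturated chain carbon bound to an aromatic nitrogen. For the measured compounds named here, the step that bears on this is the one from compound 1 to compound 3, an 8.7-fold lower number from compound 1 to compound 3 (0.94 log units; beyond the scatter), where a benzyl-type group on the triazole gave way to the ester chain. Compound 4 restores an aryl group at that place, so the reverse is expected, a number for compound 4 close to compound 1; the expected step is a 7.0-fold higher number from compound 3 to compound 4 (0.84 log units; beyond the scatter). The estimate for compound 4 is 150000 nM, ranging from 60000 nM to 400000 nM.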

Compound 4, half-maximal cytotoxic concentration: >= 156000 nM
Compound 4: only a limit was reported; the forecaster's own chance of this, stated with the estimate: 15%; at least 1.0-fold (0.01 log units) between middle value and limit.
By their numbers in this assay, from the lowest: compounds 2 and 3 (each within the scatter of the next); then compound 1.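

In this assay compound 4 gave a limit and not a number: the limit of >= 156000 nM in this assay, at which 1 of the 4 values shown sits.

Even so, the step can be read against both ester chains, with an at least 7.2-fold higher number from compound 3 to compound 4 (0.86 log units; beyond the scatter) and an at least 11-fold higher number from compound 2 to compound 4 (1.05 log units; beyond the scatter). A second aryl group, 3-nitrophenyl beside the 3-chlorophenyl of compound 1, thus goes with the high numbers at this place, while the step between compound 1 and compound 4 cannot be read, so nitro in place of chloro stays unsized.

The compounds shown leave open how an unsubstituted phenyl, or an amine in place of the nitro, would read in this assay. They also leave open whether a carboxylic acid in place of the ester would stay with compound 2 and compound 3.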